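The compounds below may be only part of what the source reports. "The series", "measured", "known", "first", "only" and "open" are said of these compounds alone.

Three compounds share one core and differ only in the amine-bearing side chain. In an assay on urine for inhibition of Myeloperoxidase (Homo sapiens) (a higher number here means a weaker inhibitor, a lower number a stronger inhibitor), compound 1 `CCN(CC)Cc1c[nH]c2ccc(F)cc12` gives 200 nM, compound 2 `CCNCCCc1c[nH]c2ccc(F)cc12` gives 300 nM, and compound 3 `CCCNCCCc1c[nH]c2ccc(F)cc12` gives 170 nM. Compound 3 has the lowest of the three numbers, yet its gaps to compound 1 and to compound 2 both stay within the scatter, so the three cannot be told apart. Compound 4 `NCCCCCCc1c[nH]c2ccc(F)cc12` carries 3-aminopropyl in place of propylamino on a saturated chain carbon, three bonds along the chain from an aromatic carbon. The two measured steps also rework this same chain: a 1.5-fold higher number from compound 1 to compound 2 (0.18 log units; within the scatter) and a 1.8-fold lower number from compound 2 to compound 3 (0.25 log units; within the scatter), and neither moves the number beyond the scatter. The change to compound 4 is therefore expected to give a 1.5-fold higher number from compound 3 to compound 4 (0.17 log units; within the scatter). For compound 4 in this assay the estimate is 250 nM, with a range from 80 nM to 800 nM.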

Compound 4, half-maximal inhibitory concentration: 260 nM
For compound 4 the middle estimate is 1.0-fold (0.02 log units) below the measured one, within the range that was stated.
By their numbers in this assay, from the lowest: compounds 3, 1, 4 and 2 (each within the scatter of the next).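

With 3-aminopropyl in place of propylamino, a 1.5-fold higher number from compound 3 to compound 4 (0.18 log units; within the scatter) appears in this assay even though the nitrogen now ends the chain instead of sitting inside it. With 3-aminopropyl in place of ethylamino, a 1.2-fold lower number from compound 2 to compound 4 (0.06 log units; within the scatter) appears as well, so among these compounds an amine at the chain end cannot be told apart from one inside the chain. Nothing available explains why this change leaves the number within the scatter. Still open, as far as these compounds go, is whether a carboxylic acid or an amide in place of the amine, or a much longer chain, would move the number beyond the scatter.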